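The source may report more compounds than this note shows. Statements on the series, on what has been measured and on what is new or still open speak of the compounds shown alone.

Compound 1 `NCCOc1ccc([C@H]2CC[C@]3(CC2)OOC2(O3)C3CC4CC(C3)CC2C4)cc1`: > 100 ug/mL
Compound 2 `c1cc([C@H]2CC[C@]3(CC2)OOC2(O3)C3CC4CC(C3)CC2C4)ccc1OCCC1CCNCC1`: > 100 ug/mL

Both entries come from a physicochemical assay for solubility, read by nephelometry, measured as kinetic solubility, with a stated time of 30 min (on this read-out higher numbers stand for higher solubility and lower numbers for lower solubility), and both are limits of the assay rather than numbers. Compound 2 gives > 100 ug/mL, which is a limit, so it has no exact place on the scale. All that the data show is the limit of > 100 ug/mL in this assay, at which 2 of the 2 values shown sit.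

Compound 3 `N[C@H]1CC[C@@H](Oc2ccc([C@H]3CC[C@]4(CC3)OOC3(O4)C4CC5CC(C4)CC3C5)cc2)CC1` keeps the shared core and changes only the group on the oxygen: 4-aminocyclohexyl in place of 2-(piperidin-4-yl)ethyl on an oxygen on an aromatic ring. In words, 4-aminocyclohexyl stands in place of 2-(piperidin-4-yl)ethyl on an oxygen on an aromatic ring.

Within the data shown here, the one measured step that bears on this change is a step that the two limits leave unreadable from compound 1 to compound 2. It alters the same side of the molecule, but it provides no size to carry over. Since a step that the two limits leave unreadable from compound 1 to compound 2 has no readable size, no step beyond the usual scatter is expected in this assay, and no direction can be expected either. The expected change is a number no higher from compound 2 to compound 3 (the limit leaves the size open). A result reported only as a limit is also expected to be the likeliest outcome.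

For compound 3 the estimate is 100 ug/mL, with an expected range of 45 ug/mL to 200 ug/mL.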

Compound 3, solubility: 25 ug/mL
For compound 3 the middle estimate is 4.0-fold (0.60 log units) above the measured one, and the stated range ends above it.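

In this assay, putting 4-aminocyclohexyl in place of 2-(piperidin-4-yl)ethyl on an oxygen on an aromatic ring gives an at least 4.0-fold lower number from compound 2 to compound 3 (0.60 log units; beyond the scatter). Putting the same group in place of 2-aminoethyl gives an at least 4.0-fold lower number from compound 1 to compound 3 (0.60 log units; beyond the scatter), so a change at this oxygen can produce a step beyond the scatter, which the earlier pair could not show. On these data alone, the step between the two earlier compounds cannot be read, and both new steps have a true size that stays open at one end, with only compound 3 carrying an exact number: the limit of > 100 ug/mL in this assay, at which 2 of the 3 values shown sit.

The 4-aminocyclohexyl group differs from the other two groups in more than one way, as it brings a carbon-only ring, has no chain between that ring and the oxygen, and has 2 defined stereocentres, so the compounds shown cannot tie the lower number to any one of these features. A compound with piperidin-4-yl on the same oxygen, or with 2-(4-aminocyclohexyl)ethyl there, would help separate the effect of the ring from that of the chain.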